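Methoxycarbonyl Replacing Methyl on a Weakly Inhibiting Scaffold

A few compounds are considered here, and "the series" means these few. Any claim that something is new, unique, unknown or untested is made for them only; others in the source may bear on it.

Compound 1, `O=C1C=CC(OC(C(F)(F)F)C(F)(F)F)N1c1ccc(Cl)cc1`, gives 4480 nM in a functional assay on K562 cells (Homo sapiens) for inhibition; a higher number here means a weaker inhibitor, a lower number a stronger inhibitor.
Compound 2, `Cc1ccc(N2C(=O)C=CC2OCC(F)(F)F)cc1`, gives 7140 nM.
Compound 3, `CC(C)NC1CC(=O)N(c2ccc(F)c(Cl)c2)C1OCC(F)(F)F`, gives 10500 nM.

All three numbers in this assay are high, so none of these compounds inhibits strongly. Compound 2 stands close to both others: its gap to compound 3 and its gap to compound 1 each fall within the usual scatter, so no order among the three can be read from these values.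

Compound 4, `COC(=O)c1ccc(N2C(=O)C=CC2OCC(F)(F)F)cc1`, differs from compound 2 by methoxycarbonyl in place of methyl on an aromatic carbon. Among the measured compounds shown here, no measured pair shows this change, so nothing here tells how this assay responds to it. Because compound 2 gives 7140 nM and the other two measured compounds sit in the same narrow band, no step beyond the scatter is expected, a 1.1-fold higher number from compound 2 to compound 4 (0.02 log units; within the scatter). Compound 4 is therefore expected at 7500 nM, with a range from 2500 nM to 22000 nM.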

Compound 4, half-maximal inhibitory concentration: 14700 nM
Compound 4: the middle estimate sits 2.0-fold (0.29 log units) below what was measured; the measured number falls inside the stated range.
By their numbers in this assay, from the lowest: compounds 1, 2, 3 and 4 (each within the scatter of the next, the first and the last beyond it).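

In this assay, among the compounds shown here, methoxycarbonyl in place of methyl, on an aromatic carbon para to a large group, gives a 2.1-fold higher number from compound 2 to compound 4 (0.31 log units; beyond the scatter) and this is the first step that can be read. It shows a modest move towards weaker inhibition at this position, so the larger group with its hydrogen-bond acceptors brings no gain here. Nothing measured on these compounds accounts for this step. On these data alone, whether a carboxylic acid, an amine or a nitrile at this position would move the number, and in which direction, stays open.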